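Swapping Methoxy for Fluoro on the Benzamide Ring

A few compounds are considered here, and "the series" means these few. Any claim that something is new, unique, unknown or untested is made for them only; others in the source may bear on it.

Compound 1 `COc1cccc(C(=O)Nc2nnc(/C=C/c3cc(OC)c(OC)c(OC)c3Br)s2)c1` — 60 nM
Compound 2 `COc1cc(/C=C/c2nnc(NC(=O)c3cccc(Cl)c3)s2)c(Br)c(OC)c1OC` — 70 nM

Of the compounds shown here, two have been measured in a functional assay on A549 cells (Homo sapiens) for antiproliferative activity, read by MTT assay, with a stated time of 48 h; a lower number here means a stronger inhibitor, a higher number a weaker inhibitor. Going by the values given here, compound 1 gives 60 nM and shows the lower of the two numbers, but its only neighbour, compound 2 with 70 nM, lies within the scatter, so the two cannot be told apart.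

Compound 3 `COc1cc(/C=C/c2nnc(NC(=O)c3cccc(F)c3)s2)c(Br)c(OC)c1OC` is the next compound to be measured. Against compound 1 the change is fluoro in place of methoxy on an aromatic carbon.

Among the compounds with values here, one measured step bears directly on this: a 1.2-fold higher number from compound 1 to compound 2 (0.07 log units; within the scatter), where the same methoxy group was replaced by chloro at the same place. That halogen exchange left the number essentially unchanged. Within the data shown here, the fluoro group is smaller still, but there is no measured step that would suggest a move in either direction, so the expectation for compound 3 is a step within the scatter, a 1.2-fold higher number from compound 1 to compound 3 (0.07 log units; within the scatter).

Compound 3 is therefore estimated to give 70 nM in this assay, with a range from 30 nM to 160 nM.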

Compound 3, half-maximal inhibitory concentration: 80 nM
Beside the measured number, compound 3's estimate is 1.1-fold (0.06 log units) below it; the measured number falls inside the stated range.
By their numbers in this assay, from the lowest: compounds 1, 2 and 3 (each within the scatter of the next).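

Going from 3-methoxyphenyl to 3-fluorophenyl gives a 1.3-fold higher number from compound 1 to compound 3 (0.12 log units; within the scatter) in this assay, even though the group that leaves counts as a hydrogen-bond acceptor and the one that enters does not. The two halogens cannot be told apart either, with a 1.1-fold higher number from compound 2 to compound 3 (0.06 log units; within the scatter) on swapping chloro for fluoro, so methoxy, chloro and fluoro, all without net charge, now read alike at this place on the ring, where before only one replacement of methoxy had been seen. For these three compounds, then, the choice among the three groups makes no measurable difference to the number, though no supporting measurement is available to explain why.

An amine or a carboxylic acid at this place, or a longer chain such as butoxy, could show whether the position responds to any group at all, since every group seen so far gives a number within the scatter of the others. On these data alone, whether methoxy, chloro and fluoro would also read alike at another carbon of this ring remains open as well.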